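The compounds below may be only part of what the source reports. "The series", "measured", "known", "first", "only" and "open" are said of these compounds alone.

Measured compounds:
compound 1 `Cc1nc(NCCNC(=O)C2CC2)nc2ccc(NC(=O)/C=C/c3ccc(OC(F)(F)F)cc3)cc12`, with 23 nM
compound 2 `Cc1ccc(/C=C/C(=O)Nc2ccc3nc(N4CCC(O)(C5CC5)CC4)nc(C)c3c2)cc1`, with 107 nM

Both were tested in a functional assay on CHO-K1 cells for antagonist activity at melanin-concentrating hormone receptor 1 (Homo sapiens), read by inositol phosphate accumulation, with stated times of 10 min and 45 min; on this read-out lower numbers stand for stronger inhibition and higher numbers for weaker inhibition. Compound 1 gives 23 nM, the lower of the two numbers; compound 2 gives 107 nM, and that gap lies beyond the usual scatter, so compound 1 stands as the more potent of the pair. Compound 3 `Cc1nc(N2CCC(N3CCCC3=O)CC2)nc2ccc(NC(=O)/C=C/c3ccc(OC(F)(F)F)cc3)cc12` has not yet been measured. It differs from compound 1 in one place: 4-(2-oxopyrrolidin-1-yl)piperidin-1-yl in place of (2-((cyclopropylcarbonyl)amino)ethyl)amino on an aromatic carbon. For the measured compounds named here, no measured pair follows this exact exchange; compound 2 also carries a piperidine on that carbon, but it differs from compound 1 elsewhere as well, so its number cannot be read as a test of this single change. The open-chain amide with its two donors becomes a ring-closed one with none, and a similar overall shape is kept. In this assay compound 3 is therefore expected to land close to compound 1, with at most a modest rise. Compound 3 is estimated at 40 nM, within a range from 12 nM to 130 nM. That corresponds to an expected step of a 1.7-fold higher number from compound 1 to compound 3 (0.24 log units; within the scatter).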

Compound 3, half-maximal inhibitory concentration: 12 nM
The estimate for compound 3 lay 3.3-fold (0.52 log units) above the measured number; the range from low to high includes it.
By their numbers in this assay, from the lowest: compounds 3 and 1 (each within the scatter of the next); then compound 2.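

In this assay, placing 4-(2-oxopyrrolidin-1-yl)piperidin-1-yl instead of (2-((cyclopropylcarbonyl)amino)ethyl)amino on the aromatic carbon between two ring nitrogen atoms gives a 1.9-fold lower number from compound 1 to compound 3 (0.28 log units; within the scatter), so the two groups cannot be told apart on this read-out. For the compounds shown here, this is the first single-place comparison at this position, and it shows that the open chain with its cyclopropane ring and hydrogen-bond donors can give way to a larger group of two non-aromatic rings with 0 hydrogen-bond donors while the number stays within the scatter. Nothing available explains why the two groups give such similar numbers.

On these data alone, it remains open whether this tolerance extends to a charged group at the same carbon, such as a primary amine or a carboxylic acid, or to a plain piperidine lacking the 2-oxopyrrolidin-1-yl ring. As far as these compounds go, it is also open how the 4-(2-oxopyrrolidin-1-yl)piperidin-1-yl group would behave alongside a different substituent on the far aromatic ring, such as a chlorine atom or a methyl group, in place of the trifluoromethoxy group.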